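The compounds below may be only part of what the source reports. "The series", "measured", "known", "first", "only" and "open" are said of these compounds alone.

Three ureas sharing one scaffold have been measured in a functional assay on OCI-Ly3 cells (Homo sapiens) for antiproliferative activity; on this read-out higher numbers stand for an effect only at larger amounts of compound and lower numbers for an effect already at smaller amounts. Compound 1 `O=C(Nc1cnc(-n2nccn2)c(Cl)c1)Nc1cnc2ccccc2c1C1CCCC1` gives 7020 nM, and compound 3 `O=C(Nc1cnc(-n2nccn2)c(Cl)c1)Nc1cnc2ccc(Cl)cc2c1C1CC1` gives 990 nM. Compound 2 `O=C(Nc1cnc(-n2nccn2)c(Cl)c1)Nc1cnc2cc(Cl)ccc2c1C1CC1` reads > 20000 nM, which is a limit of the assay and not a number. That places compound 2 at the limit of > 20000 nM in this assay, at which 1 of the 3 values shown sits. No measured pair among these compounds differs in one place alone, so no measured step bears directly on what follows.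

Going by the values given here, compound 4 `COc1ccc2c(C3CC3)c(NC(=O)Nc3cnc(-n4nccn4)c(Cl)c3)cnc2c1` has methoxy in place of chloro on an aromatic carbon, the one change from compound 2 (methoxy in place of chloro on an aromatic carbon). With compound 2 reading > 20000 nM, a limit, any number obtained next could only lie on the lower side. The step expected in this assay is a modest one toward lower numbers, an at least 3.3-fold lower number from compound 2 to compound 4 (0.52 log units; beyond the scatter), though a second limit reading would not be surprising. For compound 4 the estimate is 6000 nM, with an expected range from 1500 nM to 20000 nM.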

Compound 4, half-maximal effective concentration: > 20000 nM
Compound 4 gave a limit, no number; the forecaster's own chance of this, stated with the estimate: 35%; at least 3.3-fold (0.52 log units) between middle value and limit.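

In this assay compound 4 reads > 20000 nM, which is a limit and not a number, so no step from compound 2 to compound 4 can be read; both compounds sit at the same limit: the limit of > 20000 nM in this assay, at which 2 of the 4 values shown sit.

The compounds shown leave open whether methoxy and chloro at this place differ at all in this assay.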